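Adding a Methyl to the Hydroxy Group of Compound 2

The compounds below may be only part of what the source reports. "The series", "measured", "known", "first", "only" and "open" are said of these compounds alone.

Of the compounds shown here, two have been tested so far in a functional assay on MCF7 cells (Homo sapiens) for antiproliferative activity, read by MTT assay, with a stated time of 96 h; on this read-out higher numbers stand for weaker inhibition and lower numbers for stronger inhibition. Compound 1 (`COc1c(O)cc2cc1C[C@H](C)C[C@H](OC)[C@H](O)[C@@H](C)/C=C(\C)C[C@H](OC(N)=O)[C@@H](OC)CC/C=C(\C)C(=O)N2`) gives 8130 nM, while compound 2 (`COc1ccc([C@H]2c3cccc(c3O)NC(=O)/C(C)=C/C=C\[C@H](OC)[C@@H](OC(N)=O)/C(C)=C/[C@H](C)[C@@H](O)[C@@H](OC)C[C@@H]2C)cc1`) gives 450 nM, the lower of the two numbers, with a gap beyond the usual scatter. Compound 2 therefore stands as the stronger inhibitor of this pair. Compound 3 (`COc1ccc([C@H]2c3cccc(c3O)NC(=O)/C(C)=C/C=C\[C@H](OC)[C@@H](OC(N)=O)/C(C)=C/[C@H](C)[C@@H](OC)[C@@H](OC)C[C@@H]2C)cc1`) carries one alteration relative to compound 2: methyl in place of hydrogen on an oxygen on a saturated carbon, with methyl in place of hydrogen on an oxygen on a saturated carbon, so that hydroxy becomes methoxy. Going by the values given here, no measured pair shows what this change does, so the expectation is only a cautious one: a moderate move toward weaker inhibition, meaning a higher number. The expected size of this move is a 3.1-fold higher number from compound 2 to compound 3 (0.49 log units; beyond the scatter). For compound 3, the estimated value is 1400 nM, with an expected range from 350 nM to 5500 nM.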

Compound 3, half-maximal inhibitory concentration: 9580 nM
The estimate for compound 3 lay 6.8-fold (0.84 log units) below the measured number, and the stated range ends below it.
By their numbers in this assay, from the lowest: compound 2; then compounds 1 and 3 (each within the scatter of the next).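

In this assay, turning the hydroxy on this saturated carbon into methoxy gives a 21-fold higher number from compound 2 to compound 3 (1.33 log units; beyond the scatter) and so removes most of the inhibition seen with compound 2. This position is therefore far from indifferent: one added methyl, a single heavy atom, is enough to produce a large change on an otherwise unchanged core. Nothing available explains why the number rises so sharply.

This one step cannot separate the loss of the hydroxy hydrogen from the arrival of the methyl, since only hydroxy and methoxy appear at this place. An amine here, which keeps a hydrogen on the atom at this place, or a longer ethoxy chain could help show which of the two matters and how much more this position tolerates.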